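Trimming the ester of compound 2 to the free acid

A few compounds are considered here, and "the series" means these few. Any claim that something is new, unique, unknown or untested is made for them only; others in the source may bear on it.

Measured compounds:
compound 1, `CCOC(=O)c1c(-c2ccc(OC)c(OC)c2)csc1NC(N)=O`: 14%
compound 2, `COc1ccc(-c2csc(N)c2C(=O)OCc2ccc(F)cc2)cc1OC`: 2%

The read-out throughout is an assay on isolated protein for inhibition of protein kinase C zeta type (Homo sapiens), with stated times of 1 h and 2.5 min, tested at 30 uM; on this read-out lower numbers stand for less inhibition and higher numbers for more inhibition at the one concentration tested (going by the name of the read-out). Among the measured compounds shown here, compound 1 is the only companion to compound 2, and in this assay compound 1 gives 14%. Compound 2 gives 2%, which is the lowest of the two numbers; its gap to compound 1 is beyond the usual scatter, so compound 2 shows the weaker inhibition of the pair. For the measured compounds named here, no pair of compounds that differ in a single place has been measured, so there is no directly comparable step to lean on.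

Compound 3, `COc1ccc(-c2csc(N)c2C(=O)O)cc1OC`, has not been measured. It differs from compound 2 in one place: hydrogen in place of 4-fluorobenzyl on an oxygen next to a carbonyl group on an oxygen next to a carbonyl group whose other neighbour is the carbonyl carbon, which is the same as saying (4-fluorobenzyl)oxy becomes hydroxy. With nothing more than the low number of compound 2 to go on, the expected step of a number 3 percentage points higher from compound 2 to compound 3 (within the scatter) is small and not beyond the scatter, in no firm direction. For compound 3 the estimate is 5%, within -5% to 15%.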

Compound 3, a percentage reported as inhibition, at one concentration (the size of the read-out at that concentration, not a potency): 65%
Beside the measured number, compound 3's estimate is 60 percentage points below it, outside the stated range (above it).
By their numbers in this assay, from the lowest: compound 2; then compound 1; then compound 3.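

In this assay, putting hydrogen in place of 4-fluorobenzyl on an oxygen next to a carbonyl group gives a number 63 percentage points higher from compound 2 to compound 3 (beyond the scatter) with the rest of the structure unchanged. Among the compounds shown here, this is the first single-place comparison, and it shows that the group on this oxygen can decide whether a compound shows almost no inhibition or a clear one at the one concentration tested. Nothing available gives a reason for the size of this step.

A single step cannot separate two readings: the free hydroxy may itself matter, or it may be enough for the 4-fluorobenzyl to be gone, and a methyl ester, a primary amide or a tetrazole at this carbonyl would help tell these apart. Also open, from the compounds shown here alone, is how potent compound 3 really is, since a single concentration gives no potency, and whether the same change would have a similar effect on a compound carrying a different group on the ring nitrogen, such as an acetamide.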